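Changing the amide substituent: expected cytotoxicity of compound 4

The source may report more compounds than this note shows. Statements on the series, on what has been measured and on what is new or still open speak of the compounds shown alone.

Compound 1 `CC(C)Cc1nn(-c2cccc(F)c2)cc1C(=O)NCc1ccc(F)cc1` has been tested in a toxicity assay on HepG2 2.2.15 cells (Homo sapiens) for cytotoxicity, read by CCK-8 assay, with a stated time of 8 days; on this read-out lower numbers stand for higher toxicity in this test and higher numbers for lower toxicity in this test. In this assay compound 1 gives only a limit, > 100000 nM. Compound 2 `CCOC(=O)c1cn(-c2ccc(C(=O)O)cc2)nc1CC(C)C` also reaches only a limit in this assay, > 100000 nM. Compound 3 `CC(C)Cc1nn(-c2nccs2)cc1C(=O)NCc1ccc(F)cc1` likewise gives a limit in this assay, > 100000 nM. For the measured compounds named here, the single step between neighbours, a step that the two limits leave unreadable from compound 1 to compound 3, therefore cannot be sized, and the wider picture is the limit of > 100000 nM in this assay, at which 3 of the 3 values shown sit.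

Compound 4 `CC(C)Cc1nn(-c2cccc(F)c2)cc1C(=O)NNc1ccc(F)cc1` differs from compound 1 in one place: (4-fluorophenyl)amino in place of 4-fluorobenzyl on an amide-type nitrogen. No measured step covers this kind of change, and the one step that exists is unreadable, so nothing shown points to a toxicity that would be reached within the tested range. For compound 4 the expected step that the limit leaves unreadable from compound 1 to compound 4 is none beyond the scatter, resting on compound 1 at > 100000 nM. Compound 4 is accordingly estimated at 150000 nM in this assay, within a range from 40000 nM to 600000 nM, most likely reported again as a limit.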

Compound 4, half-maximal cytotoxic concentration: 45400 nM
The estimate for compound 4 lay 3.3-fold (0.52 log units) above the measured number, and the stated range covers the measured number.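

Placing (4-fluorophenyl)amino instead of 4-fluorobenzyl on the amide-type nitrogen gives the first readable change in this assay, an at least 2.2-fold lower number from compound 1 to compound 4 (0.34 log units; beyond the scatter). For the compounds shown here, this shows that the group at this position can shift the result towards higher toxicity in this test, which the earlier compounds could not show, as the steps among them cannot be read. Compound 4 is also the only compound shown with a measured number rather than a limit: the limit of > 100000 nM in this assay, at which 3 of the 4 values shown sit.

Going by these compounds, it remains open whether the same change would have a similar effect with the 1,3-thiazol-2-yl group of compound 3 in place of 3-fluorophenyl. A 2-(4-fluorophenyl)ethyl chain, with carbon where the new nitrogen stands, would help show whether that nitrogen and its hydrogen go with the shift or whether the change in chain alone is enough.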